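This account rests on a few compounds, and the source may have more. Where it says the series, first, only, none or still open, it means among the compounds named here.

Of the compounds shown here, two of a shared core have been tested in a functional assay on the whole organism with Rattus norvegicus as the target; a lower number here means that less compound is needed, a higher number that more compound is needed for the effect. Compound 1 `Cc1nn(C)c2c1C(c1cccc(Cl)c1)=NCC(=O)N2` carries a 3-chlorophenyl group; in this assay compound 1 reaches only a limit of the measurement, > 500 mg/kg. Compound 2 `CCCCn1nc(C)c2c1NC(=O)CN=C2c1ccccc1Cl` carries a butyl chain and a 2-chlorophenyl group; in this assay compound 2 gives 32 mg/kg. For the measured compounds named here, compound 2 thus holds the only real number so far, since compound 1 sits at the limit of > 500 mg/kg in this assay, at which 1 of the 2 values shown sits, and offers no number to compare against.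

Compound 3 `CCCCn1nc(C)c2c1NC(=O)CN=C2c1cccc(Cl)c1` has not yet been measured. It keeps the butyl chain of compound 2 and changes only the aryl group: 3-chlorophenyl in place of 2-chlorophenyl on a carbon with a double bond to nitrogen. Compound 1, the other 3-chlorophenyl compound, gave no number, so a step from compound 2 to compound 3 towards a higher dose is expected, with a fair chance that again only a limit is found. For compound 3 the expected dose is 150 mg/kg, within 50 mg/kg to 500 mg/kg, a step of a 4.7-fold higher number from compound 2 to compound 3 (0.67 log units; beyond the scatter).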

Compound 3, minimum effective dose: > 500 mg/kg
Compound 3 ended at the assay's limit; the forecaster's own chance of this, stated with the estimate: 30%; at least 3.3-fold (0.52 log units) between middle value and limit.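

In this assay, 3-chlorophenyl in place of 2-chlorophenyl on the carbon with a double bond to nitrogen gives an at least 15-fold higher number from compound 2 to compound 3 (1.19 log units; beyond the scatter), with the butyl chain and the rest of the molecule unchanged. The result for compound 3 is a limit of the assay and not a number, yet the pair shows that at this carbon the place of the chlorine on the phenyl group matters greatly, although both compounds have the same atoms. The step from compound 1 to compound 3 cannot be read, because both values are limits: the limit of > 500 mg/kg in this assay, at which 2 of the 3 values shown sit.

Still open, from the compounds shown here alone, is whether a 4-chlorophenyl or an unsubstituted phenyl group on this carbon would match compound 2 or compound 3. Also open, going by these compounds, is what a hexyl chain in place of butyl would do alongside 2-chlorophenyl.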